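A few compounds are considered here, and "the series" means these few. Any claim that something is new, unique, unknown or untested is made for them only; others in the source may bear on it.

Compound 3, with the structure `Clc1[nH]ccc2ncnc1-2`, gives 6% in a functional assay (Homo sapiens) for inhibition of Nucleic Acid, tested at 100 uM; a lower number here means less inhibition, a higher number more inhibition at the concentration tested (going by the name of the read-out). Among the three compounds measured so far it stands second highest, though that ranking rests on small margins. Its nearest neighbour is compound 1, `CSc1[nH]ccc2ncnc1-2`, which gives 4%; the step of a number 2 percentage points higher from compound 1 to compound 3 (within the scatter) lies within the scatter, so the two cannot be told apart. The furthest is compound 2, `CNc1[nH]ccc2ncnc1-2`, which gives 18%; the step of a number 12 percentage points lower from compound 2 to compound 3 (beyond the scatter) is beyond the scatter.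

Compound 4, `Nc1[nH]ccc2ncnc1-2`, differs from compound 3 in one place: amino in place of chloro on an aromatic carbon. Going by the values given here, two measured steps bear on this. Replacing methylamino with chloro, a number 12 percentage points lower from compound 2 to compound 3 (beyond the scatter), lowered inhibition modestly, and replacing methylsulfanyl with methylamino, a number 14 percentage points higher from compound 1 to compound 2 (beyond the scatter), raised it modestly. Both point the same way: a group carrying a hydrogen-bond donor and acceptor on this carbon sat higher than chloro or methylsulfanyl. Amino shares those counted features with methylamino, so a modest rise from compound 3 is expected, about the size of a number 10 percentage points higher from compound 3 to compound 4 (within the scatter). Compound 4 is therefore estimated to give about 16% in this assay, with a plausible range from 4% to 30%.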

Compound 4, a percentage reported as inhibition, at one concentration (the size of the read-out at that concentration, not a potency): 60%
Estimate against measurement, compound 4: 44 percentage points below; the measured number lies above the stated range.
By their numbers in this assay, from the lowest: compounds 1 and 3 (each within the scatter of the next); then compound 2; then compound 4.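

Going by these compounds alone, on this aromatic carbon, next to the ring nitrogen, amino stands well apart from the other groups in this assay: the change from chloro gives a number 54 percentage points higher from compound 3 to compound 4 (beyond the scatter) and the change from methylsulfanyl gives a number 56 percentage points higher from compound 1 to compound 4 (beyond the scatter) in a series where no earlier step was more than modest. The new finding is how much a single methyl on the nitrogen matters, since hydrogen in place of that methyl gives a number 42 percentage points higher from compound 2 to compound 4 (beyond the scatter) even though amino and methylamino share the same counted hydrogen-bond features, so neither a nitrogen on this carbon nor those features alone separate compound 2 from compound 4. No measurement shown here accounts for the size of these steps.

As far as these compounds go, whether a dimethylamino group, a longer ethylamino chain or a hydroxyl on this carbon would fall near compound 2 or near compound 4 remains open, and so does whether the drop from amino to methylamino depends on the size of the added group. From the compounds shown here alone, each number also comes from a single concentration, so how compound 4 compares in potency with the others remains unknown.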